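Shortening the Carbonate Chain: From Compound 3 to Compound 4

The compounds below may be only part of what the source reports. "The series", "measured", "known", "first", "only" and "open" are said of these compounds alone.

Measured compounds:
compound 1 `O=C(OCCO)OCCc1ccc(O)c(O)c1` — "not determined" (no result reported)
compound 2 `CCCCOC(=O)OCCc1ccc(O)c(O)c1` — "not determined" (no result reported)
compound 3 `CCCCCCCCCCCCOC(=O)OCCc1ccc(O)c(O)c1` — 12400 nM

Three carbonate esters of the same catechol-bearing core were studied in an ADME assay on MRC5 cells (Homo sapiens) for inhibition, read by MTT assay, with a stated time of 72 h; a lower number here means a stronger inhibitor, a higher number a weaker inhibitor. For compound 1 the result is "not determined" (no result reported), and for compound 2 it is "not determined" (no result reported). Within the data shown here, compound 3 is therefore the only one with a number: in this assay compound 3 gives 12400 nM, a weak result, and with no other number beside it there is nothing to rank it against.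

Compound 4 `CCCCCCCCCOC(=O)OCCc1ccc(O)c(O)c1` is the next compound. Its difference from compound 3 is hydrogen in place of propyl on a saturated chain carbon, nine bonds along the chain from an oxygen next to a carbonyl group. The chain grows shorter; everything else, the carbonate linker and the core, stays the same.

Among the measured compounds shown here, no step between measured compounds is available, so the size of this change can only be guessed. The expectation is a small step of a 1.6-fold higher number from compound 3 to compound 4 (0.21 log units; within the scatter), probably toward a slightly weaker result, and possibly no larger than the scatter. Compound 4 is expected to give about 20000 nM in this assay, within a range of 8000 nM to 50000 nM.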

Compound 4, half-maximal inhibitory concentration: 15900 nM
Beside the measured number, compound 4's estimate is 1.3-fold (0.10 log units) above it; the range from low to high includes it.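

In this assay, hydrogen in place of propyl on a saturated chain carbon, nine bonds along the chain from an oxygen next to a carbonyl group, gives a 1.3-fold higher number from compound 3 to compound 4 (0.11 log units; within the scatter). Among these compounds, this is the first step that can be read, and it shows that the chain can lose these three carbons with no difference that stands out from the usual scatter of repeated measurements. Nothing available explains this result, so no cause can be given for it.

Steps involving compound 1 or compound 2 cannot be read, as their entries hold no number. Also open, on these data alone, is what a chain ending in an amine or a carboxylic acid, or a chain longer than that of compound 3, would give in this assay.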